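Second Methyl on the Pyridine Ring: Expected Binding

The source may hold more compounds than are shown below. What is called first, only, known or untested is meant among the compounds shown, and "the series" means these compounds.

Compound 1 `CCCN(CCC)c1cc(C)nc2c(-c3ccc(N(C)C)nc3)c(C)nn12` — in an assay on CHO cells for binding affinity to corticotropin-releasing factor receptor 1 (Homo sapiens) (a lower number here means a stronger inhibitor, a higher number a weaker inhibitor), compound 1 gives 4.2 nM
Compound 2 `CCCN(CCC)c1cc(C)nc2c(-c3ccc(N(C)C)nc3C)c(C)nn12` — in this assay compound 2 gives 2.2 nM

Going by the values given here, only two compounds have been measured, and they sit close together: the step of a 1.9-fold lower number from compound 1 to compound 2 (0.28 log units; within the scatter) is within the scatter of the method, so compound 2 and compound 1 cannot be told apart on these numbers, even though compound 2 carries the smaller value of the pair.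

Compound 3 `CCCN(CCC)c1cc(C)nc2c(-c3c(C)cc(N(C)C)nc3C)c(C)nn12` has not yet been measured. It differs from compound 2 by methyl in place of hydrogen on an aromatic carbon. Among the compounds with values here, the only measured step that bears on this change is the one from compound 1 to compound 2, which also added a methyl to an aromatic carbon of the same ring, and that step stayed within the scatter. With one such step, and nothing on this particular position, there is no ground to expect a move beyond the scatter in either direction in this assay.

For compound 3 the expected value is therefore 2.5 nM, with a range of 0.8 nM to 8 nM. The step from compound 2 to compound 3 is thus estimated as a 1.1-fold higher number from compound 2 to compound 3 (0.06 log units; within the scatter).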

Compound 3, inhibition constant: 5.2 nM
Beside the measured number, compound 3's estimate is 2.1-fold (0.32 log units) below it; the measured number falls inside the stated range.
By their numbers in this assay, from the lowest: compounds 2, 1 and 3 (each within the scatter of the next, the first and the last beyond it).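

In this assay a methyl on the aromatic carbon opposite the ring nitrogen, ortho to a large group, gives a 2.4-fold higher number from compound 2 to compound 3 (0.37 log units; beyond the scatter) and so weakens binding modestly, by more than the scatter of the method. The earlier methyl on this ring, on a different carbon, gave a 1.9-fold lower number from compound 1 to compound 2 (0.28 log units; within the scatter) and could not be told apart from no change, so the same swap of hydrogen for methyl does not read the same at both places on this ring. The data offer no explanation for this difference between the two positions.

The compounds shown leave open whether the methyl on this carbon would give a similar step in a ring that lacks the other methyl, since this change has been read only with that methyl in place. They also leave open how other groups on this same carbon, such as an ethyl, a methoxy group or a chlorine atom, would compare with hydrogen and with methyl.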